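A few compounds are considered here, and "the series" means these few. Any claim that something is new, unique, unknown or untested is made for them only; others in the source may bear on it.

Measured so far:
Compound 1 `COc1ccc(-c2cn(C/C=C3\OC(=O)C(OCc4ccccc4)=C3OCc3ccccc3)nn2)cc1` gives > 100000 nM in a functional assay on SW-620 cells (Homo sapiens) for antiproliferative activity, read by MTT assay, with a stated time of 72 h (on this read-out higher numbers stand for weaker inhibition and lower numbers for stronger inhibition), which is a limit of the assay.
Compound 2 `Cc1ccc(S(=O)(=O)NCc2cn(C[C@H](O)[C@H]3OC(=O)C(OCc4ccccc4)=C3OCc3ccccc3)nn2)cc1` gives 45800 nM in this assay.
Compound 3 `Cc1ccc(-c2cn(C/C=C3\OC(=O)C(OCc4ccccc4)=C3OCc3ccccc3)nn2)cc1` gives > 100000 nM in this assay, again a limit of the assay.

Among the measured compounds shown here, compound 2 therefore stands as the only compound of the three with a number in this assay; the other two are limits. For the measured compounds named here, the one step between measured compounds that differ in a single place, a step that the two limits leave unreadable from compound 1 to compound 3, cannot be read in size, since both ends sit at the limit of > 100000 nM in this assay, at which 2 of the 3 values shown sit. Going by the values given here, no measured step touches the place that changes on the way to compound 4.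

Compound 4 `C[Si](C)(C)c1cn(C[C@H](O)[C@H]2OC(=O)C(OCc3ccccc3)=C2OCc2ccccc2)nn1` differs from compound 2 in one place: a group of 4 heavy atoms (3 carbon, 1 silicon; no ring) in place of a group of 12 heavy atoms (8 carbon, 1 nitrogen, 2 oxygen, 1 sulfur; one six-membered aromatic ring of carbon only), on an aromatic carbon. Among the compounds with values here, neither the change in compound 1 and compound 3 nor anything else in the set speaks to this replacement, so there is no measured step to lean on. Compound 2 is itself weak in this assay, and a change of this size at the five-membered ring leaves the outcome open in both directions.

Within the data shown here, with no step to guide it, compound 4 is expected to land close to compound 2, an estimated step of a 1.1-fold higher number from compound 2 to compound 4 (0.04 log units; within the scatter) within the scatter, giving an estimate of 50000 nM in this assay, with a range from 15000 nM to 100000 nM and a real chance that only a limit is reported.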

Compound 4, half-maximal inhibitory concentration: 56000 nM
For compound 4 the middle estimate is 1.1-fold (0.05 log units) below the measured one, within the range that was stated.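

Among the compounds shown here, on the aromatic carbon of the five-membered aromatic ring, the first readable step in this assay is a 1.2-fold higher number from compound 2 to compound 4 (0.09 log units; within the scatter). For the compounds shown here, the (((4-methylphenyl)sulfonyl)amino)methyl group, with its six-membered aromatic ring, hydrogen-bond donor and 2 hydrogen-bond acceptors, gives way to a group of 4 heavy atoms, 3 carbon and 1 silicon, with no ring, and the read-out shows no change that can be told from scatter; no earlier step touched this position. This is also the first comparison in the set with a number at both ends, and numbers remain scarce: the limit of > 100000 nM in this assay, at which 2 of the 4 values shown sit.

Two very different groups at this carbon thus give the same weak level, but two groups cannot show whether any group here could lift the activity of this series. From the compounds shown here alone, whether an amine, a carboxylic acid or a longer alkyl chain on this carbon would move the number beyond the scatter stays open, as does whether the same tolerance would hold if the rest of the core of compound 2 were changed.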